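This account rests on a few compounds, and the source may have more. Where it says the series, first, only, none or still open, it means among the compounds named here.

The measured compounds are:
compound 1, `Cc1noc(C)c1-c1cnc(N)c(Oc2ccc(C(=O)NC3CCCC3)cc2)n1`, with 25200 nM in a functional assay on LoVo cells (Homo sapiens) for inhibition, read by MTT assay, with a stated time of 72 h; on this read-out higher numbers stand for weaker inhibition and lower numbers for stronger inhibition;
compound 2, `Cc1noc(C)c1-c1cnc(N)c(Oc2ccc(C(=O)Nc3ccccc3)cc2)n1`, with 5740 nM in this assay;
compound 3, `Cc1noc(C)c1-c1cnc(N)c(Oc2ccc(C(=O)Nc3ccc(Cl)cc3)cc2)n1`, with 1920 nM in this assay.

Compound 1 has the highest number of the three in this assay, so it is the weakest inhibitor among them; its steps to both other compounds lie beyond the scatter. Compound 4, `Cc1noc(C)c1-c1cnc(N)c(Oc2ccc(C(=O)Nc3ccc(Cl)cn3)cc2)n1`, is not yet measured. It differs from compound 1 in one place: 5-chloropyridin-2-yl in place of cyclopentyl on an amide-type nitrogen. For the measured compounds named here, two measured steps bear on this change, both of which replace the cyclopentyl on the amide-type nitrogen with a six-membered aromatic ring: a 4.4-fold lower number from compound 1 to compound 2 (0.64 log units; beyond the scatter) and a 13-fold lower number from compound 1 to compound 3 (1.12 log units; beyond the scatter). The further step a 3.0-fold lower number from compound 2 to compound 3 (0.48 log units; beyond the scatter) lies in the same direction. Since compound 4 carries a chloro-bearing six-membered aromatic ring at that position, as compound 3 does, a step of comparable size is expected: a 10-fold lower number from compound 1 to compound 4 (1.00 log units; beyond the scatter). Compound 4 is therefore estimated at 2500 nM, within a range from 800 nM to 8000 nM.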

Compound 4, half-maximal inhibitory concentration: 9180 nM
Beside the measured number, compound 4's estimate is 3.7-fold (0.56 log units) below it; the whole stated range lies below it.
By their numbers in this assay, from the lowest: compound 3; then compounds 2 and 4 (each within the scatter of the next); then compound 1.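

In this assay, 5-chloropyridin-2-yl on the amide-type nitrogen still improves on cyclopentyl, with a 2.7-fold lower number from compound 1 to compound 4 (0.44 log units; beyond the scatter), but this step is smaller than the one to the 4-chlorophenyl of compound 3. Exchanging 4-chlorophenyl for 5-chloropyridin-2-yl thus costs much of that improvement, with a 4.8-fold higher number from compound 3 to compound 4 (0.68 log units; beyond the scatter), and the result with a 1.6-fold higher number from compound 2 to compound 4 (0.20 log units; within the scatter) places compound 4 within the scatter of the plain phenyl of compound 2, so the chloro gain seen on phenyl does not carry over to this ring. Nothing measured here explains this loss.

The compounds shown leave open what an unsubstituted pyridin-2-yl would give, which would separate the effect of the ring nitrogen from that of the chloro. As far as these compounds go, it also remains open whether a methoxy group or a nitrile in place of the chloro would match compound 3.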